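A few compounds are considered here, and "the series" means these few. Any claim that something is new, unique, unknown or untested is made for them only; others in the source may bear on it.

The measured compounds and their values in a functional assay on MDA-MB-231 cells (Homo sapiens) for antiproliferative activity, read by MTT assay, with a stated time of 48 h (on this read-out higher numbers stand for weaker inhibition and lower numbers for stronger inhibition), are:

Compound 1, `C/C(=C\CC/C(C)=C/CC[C@@H]1[C@@]2(C)CCC(=O)C(C)(C)[C@H]2CC[C@@]1(C)O)CC/C=C(\C)C(=O)OCc1cn(-c2cccc(O)c2)nn1`, gives 139000 nM.
Compound 2, `C/C(=C\CC/C(C)=C/CC[C@@H]1[C@@]2(C)CCC(=O)C(C)(C)[C@H]2CC[C@@]1(C)O)CC/C=C(\C)C(=O)OCc1cn(-c2ccccc2C(F)(F)F)nn1`, gives > 150000 nM, which is a limit of the assay and not a number.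
Compound 3, `C/C(=C\CC/C(C)=C/CC[C@@H]1[C@@]2(C)CCC(=O)C(C)(C)[C@H]2CC[C@@]1(C)O)CC/C=C(\C)C(=O)OCc1cn(-c2ccccc2)nn1`, gives > 150000 nM, likewise a limit of the assay and not a number.

Compound 3 therefore stands only at the limit of > 150000 nM in this assay, at which 2 of the 3 values shown sit, with no measured number of its own. The step from compound 1 reads an at least 1.0-fold higher number from compound 1 to compound 3 (0.03 log units; that floor lies within the scatter), a floor that lies within the scatter, and the step that the two limits leave unreadable from compound 2 to compound 3 cannot be read because both ends are limits.

Compound 4, `C/C(=C\CC/C(C)=C/CC[C@@H]1[C@@]2(C)CCC(=O)C(C)(C)[C@H]2CC[C@@]1(C)O)CC/C=C(\C)C(=O)OCc1cn(-c2cccc(Cl)c2)nn1`, differs from compound 3 by chloro in place of hydrogen on an aromatic carbon. Going by the values given here, no measured step bears directly on this change; the only step into compound 3 is an at least 1.0-fold higher number from compound 1 to compound 3 (0.03 log units; that floor lies within the scatter), and the step of an at least 1.0-fold higher number from compound 1 to compound 2 (0.03 log units; that floor lies within the scatter) concerns a different group. Since compound 3 already sits at the limit, the step that the limit leaves unreadable from compound 3 to compound 4 is expected to stay near that limit rather than show a readable change. The value of compound 4 in this assay is estimated at 200000 nM, within 90000 nM to 500000 nM, and is expected most likely to be reported as a limit again.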

Compound 4, half-maximal inhibitory concentration: 103000 nM
Estimate against measurement, compound 4: 1.9-fold (0.29 log units) above; the measured number falls inside the stated range.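

In this assay, a chloro on the six-membered aromatic ring, meta to a large group, gives a measured number rather than a limit, yet the readings are only an at least 1.4-fold lower number from compound 3 to compound 4 (0.16 log units; that floor lies within the scatter) and an at least 1.4-fold lower number from compound 2 to compound 4 (0.16 log units; that floor lies within the scatter), so neither comparison shows a real gain in inhibition. Against the hydroxy group at the same place, the change reads as a 1.3-fold lower number from compound 1 to compound 4 (0.13 log units; within the scatter), so two quite different groups on this ring cannot be told apart here, and both numbers remain very high on this read-out. Compound 3 stays a limit of the assay and not a number, compound 2 does likewise, and steps with a limit at both ends cannot be read: the limit of > 150000 nM in this assay, at which 2 of the 4 values shown sit.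

Going by these compounds, what an amine, a carboxylic acid or a methoxy group would do at this same place stays open, so it cannot be said whether any group on this ring can move the number clearly beyond the scatter. Also open, on these data alone, is whether an amide in place of the ester, or a longer chain linking the aromatic part to the shared core, would change the reading.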